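A few compounds are considered here, and "the series" means these few. Any claim that something is new, unique, unknown or untested is made for them only; others in the source may bear on it.

Notes on the series. For the measured compounds named here, in an ADME assay on HEp-2 cells (Homo sapiens) for cytotoxicity, read by MTT assay, with a stated time of 72 h (on this read-out higher numbers stand for weaker inhibition and lower numbers for stronger inhibition), compound 1 (`COc1ccc(C2=C(c3cc(OC)c(OC)c(OC)c3)C(=O)C(OC(C)=O)C2)cc1`) gives 18 ug/mL as the only plain number so far. Compound 2 (`COc1ccc(C2=C(c3cc(OC)c(OC)c(OC)c3)C(=O)C(OC(C)=O)C2)cc1F`) stands at < 1 ug/mL in this assay and this is a limit of the assay, not a number.

The next analogue is compound 3 (`COc1ccc(C2=C(c3cc(OC)c(OC)c(OC)c3)C(=O)C(OC(C)=O)C2)cc1Cl`), with chloro in place of fluoro on an aromatic carbon, ortho to a methoxy group and meta to a large group (chloro in place of fluoro on an aromatic carbon), which turns 3-fluoro-4-methoxyphenyl into 3-chloro-4-methoxyphenyl. Going by the values given here, one measured step bears on this change: an at least 18-fold lower number from compound 1 to compound 2 (1.25 log units; beyond the scatter) is large and has fluoro in place of hydrogen on that same aromatic carbon. It does not compare fluoro with chloro, so it sets no size for this change. Compound 3 also carries no hydrogen on that carbon, so the lower number in an at least 18-fold lower number from compound 1 to compound 2 (1.25 log units; beyond the scatter) is expected largely to hold in this assay with no firm direction. The estimated step is a step that the limit leaves unreadable from compound 2 to compound 3 and it is expected to stay within the scatter. For compound 3 the estimate is 0.8 ug/mL with an expected range of 0.2 ug/mL to 4 ug/mL in this assay and a report as a limit is quite possible.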

Compound 3, half-maximal inhibitory concentration: < 1 ug/mL
Compound 3 was reported as a limit; the forecaster's own chance of this, stated with the estimate: 55%; the middle value lies beyond the limit too.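

In this assay, chloro on this aromatic carbon, ortho to a methoxy group, gives an at least 18-fold lower number from compound 1 to compound 3 (1.25 log units; beyond the scatter), so the large step seen with fluoro is no longer tied to fluoro alone and now holds for two substituents in place of hydrogen at this one position. The step between the fluoro and chloro compounds cannot be read, so the 3-fluoro-4-methoxyphenyl and 3-chloro-4-methoxyphenyl compounds cannot be put in any order and no size can be given for this change. Compound 2 and compound 3 are both reported only as limits, and any comparison between them stops there: the limit of < 1 ug/mL in this assay, at which 2 of the 3 values shown sit.

Still open, going by these compounds, is whether a step of this size needs fluoro or chloro at all, or whether a methyl, a hydroxyl or an amine on the same aromatic carbon would lower the number as far. Also open, on these data alone, is how far compound 2 and compound 3 truly lie past their limit, and whether the step would hold on the shared core if a free hydroxyl or an amine took the place of the acetate.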